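A few compounds are considered here, and "the series" means these few. Any claim that something is new, unique, unknown or untested is made for them only; others in the source may bear on it.

The compounds measured in a functional assay on K562 cells (Homo sapiens) for inhibition, read by MTT assay, with a stated time of 72 h; on this read-out higher numbers stand for weaker inhibition and lower numbers for stronger inhibition:
compound 1, `CCc1cc(CC)c(C(=O)/C=C/C(=O)O)c(CC)c1`, gives 4010 nM;
compound 2, `CCc1ccc(C(=O)/C=C/C(=O)O)cc1`, gives 5530 nM;
compound 3, `O=C(O)/C=C/C(=O)c1ccc(Br)cc1`, gives 11200 nM.

Compound 3 stands highest of the three numbers in this assay, with compound 2 nearest and compound 1 furthest below it. Among the measured compounds shown here, the only single-change step measured so far is a 2.0-fold higher number from compound 2 to compound 3 (0.31 log units; beyond the scatter), a modest move to a higher number when bromo replaces ethyl on an aromatic carbon.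

Compound 4, `CC(C)c1ccc(C(=O)/C=C/C(=O)O)cc1`, differs from compound 3 by isopropyl in place of bromo on an aromatic carbon. This change undoes the bromo for an alkyl group, much as ethyl stands in compound 2, so the measured step bears on it directly, in reverse. A lower number of about the same modest size is therefore expected for compound 4 in this assay, with no ground in the data for anything larger. Compound 4 is estimated at 5500 nM, within a range of 2800 nM to 11000 nM. This estimate for compound 4 amounts to an expected step of a 2.0-fold lower number from compound 3 to compound 4 (0.31 log units; beyond the scatter).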

Compound 4, half-maximal inhibitory concentration: 5560 nM
Compound 4: the middle estimate sits 1.0-fold (0.00 log units) below what was measured; measured number inside the range.
By their numbers in this assay, from the lowest: compounds 1, 2, 4 and 3 (each within the scatter of the next, the first and the last beyond it).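

In this assay the extra methyl on the saturated chain carbon, which turns ethyl into isopropyl, gives a 1.0-fold higher number from compound 2 to compound 4 (0.00 log units; within the scatter) and so leaves the number unresolved, meaning that branching at this carbon has no visible effect on this read-out. Bromo and isopropyl, however, give a 2.0-fold lower number from compound 3 to compound 4 (0.30 log units; within the scatter) and are not separated here, whereas ethyl and bromo give a 2.0-fold higher number from compound 2 to compound 3 (0.31 log units; beyond the scatter) and are, so the bromo gap is resolved for only one of the two alkyl groups and only narrowly. Nothing measured here explains these numbers.

From the compounds shown here alone, it remains open whether a longer chain, a methoxy group or an amine on this same aromatic carbon would read like the alkyl groups or like bromo. Going by these compounds, how far the alkyl tolerance extends, for instance to tert-butyl, also stays unknown.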